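The source may hold more compounds than are shown below. What is called first, only, known or untested is meant among the compounds shown, and "the series" means these compounds.

Measured compounds:
compound 1, `CC(C)OC(=O)N1CCC(Oc2ncnc3c2CCN3c2ccc(S(C)(=O)=O)cc2F)CC1`: 50.1 nM
compound 2, `CC(C)(C)COC(=O)N1CCC(Oc2ncnc3c2CCN3c2ccc(S(C)(=O)=O)cc2F)CC1`: 39.8 nM

In a functional assay on CHO-K1 cells for agonist activity at Glucose-dependent insulinotropic receptor (Homo sapiens), read by a luciferase reporter, with a stated time of 5 h (a lower number here means that less compound is needed, a higher number that more compound is needed for the effect), compound 1 gives 50.1 nM, and compound 2 gives 39.8 nM. Going by the values given here, compound 1 stands beside only one neighbour, and the step of a 1.3-fold lower number from compound 1 to compound 2 (0.10 log units; within the scatter) shows that the two measured numbers cannot be told apart. That step concerns the neopentyl in place of isopropyl on an oxygen next to a carbonyl group and leaves the rest of the shared core untouched.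

Compound 3, `CC(C)OC(=O)N1CCC(Oc2ncnc3c2CCN3c2ccc(F)cn2)CC1`, has not yet been measured in this assay. It differs from compound 1 in this way: 5-fluoropyridin-2-yl in place of 2-fluoro-4-(methylsulfonyl)phenyl on a nitrogen on an aromatic ring in a ring. Among the compounds with values here, the single measured step bears on a different place of the molecule and therefore gives no guidance on the size or direction of the change from compound 1 to compound 3. Within the data shown here, with no comparable step among the measured compounds, the expectation for compound 3 rests on the structural change alone and must be wide. Compound 3 is estimated at 120 nM, with a range from 30 nM to 600 nM, which would mean an expected step of a 2.4-fold higher number from compound 1 to compound 3 (0.38 log units; beyond the scatter).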

Compound 3, half-maximal effective concentration: > 10000 nM
Compound 3 gave a limit, no number; the forecaster's own chance of this, stated with the estimate: 10%; middle value at least 83-fold (1.92 log units) from the limit.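

The value for compound 3 is a limit of the assay and not a number: the limit of > 10000 nM in this assay, at which 1 of the 3 values shown sits. In this assay, exchanging 2-fluoro-4-(methylsulfonyl)phenyl for 5-fluoropyridin-2-yl on the nitrogen gives an at least 190-fold higher number from compound 1 to compound 3 (2.30 log units; beyond the scatter). Going by these compounds alone, the earlier change, on an oxygen next to a carbonyl group, gave only a 1.3-fold lower number from compound 1 to compound 2 (0.10 log units; within the scatter), so this nitrogen position is the first place where a single change separates two compounds clearly, and the activity of compound 1 depends on what it carries there.

The step from compound 1 to compound 3 changes the ring atoms and removes the methylsulfonyl group together, so the compounds shown leave open which of these accounts for it. They also leave open whether a nitrile or a sulfonamide in place of the methylsulfonyl group would retain the activity of compound 1.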